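Fluoro for Chloro on the Benzoyl Ring

The compounds below may be only part of what the source reports. "The series", "measured", "known", "first", "only" and "open" are said of these compounds alone.

Measured compounds:
compound 1 `CN(C)c1ccc(C(=O)c2cc(/C=C/C(=O)NO)n(C)c2)cc1` — 88%
compound 2 `Cn1cc(C(=O)c2ccc(Cl)cc2)cc1/C=C/C(=O)NO` — 87%
compound 3 `Cn1cc(C(=O)c2ccccc2)cc1/C=C/C(=O)NCCO` — 0.9%

In an assay on isolated protein for inhibition of histone deacetylase HD2 (Zea mays), tested at 30 uM (a higher number here means more inhibition at the concentration tested (going by the name of the read-out), a lower number less inhibition), compound 1 gives 88% and compound 2 gives 87%, while compound 3 gives only 0.9%. Compound 2 thus stands second highest of the three numbers; its nearest neighbour is compound 1, a difference within the scatter, and its furthest is compound 3, far below and beyond the scatter. Compound 3 differs from compound 2 at the amide end rather than on the aryl ring, so its value says nothing about changes there.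

Within the data shown here, the only measured step at the relevant aromatic carbon is a number 1 percentage points lower from compound 1 to compound 2 (within the scatter): a swap of one group for another at that position, within the scatter.

Compound 4 `Cn1cc(C(=O)c2ccc(F)cc2)cc1/C=C/C(=O)NO` remains to be measured. fluoro in place of chloro on an aromatic carbon Because a number 1 percentage points lower from compound 1 to compound 2 (within the scatter) stayed within the scatter, a second exchange of a small group at the same carbon is expected to produce no step beyond the scatter. The expected step is a number 2 percentage points lower from compound 2 to compound 4 (within the scatter). Compound 4 is therefore estimated at 85%, within a range from 70% to 95%.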

Compound 4, a percentage reported as inhibition, at one concentration (the size of the read-out at that concentration, not a potency): 84%
For compound 4 the middle estimate is 1 percentage points above the measured one, within the range that was stated.
By their numbers in this assay, from the lowest: compound 3; then compounds 4, 2 and 1 (each within the scatter of the next).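

Exchanging one halogen for another at this aromatic carbon gives, in this assay, a number 3 percentage points lower from compound 2 to compound 4 (within the scatter), so the 4-fluorophenyl compound holds the level of the 4-chlorophenyl compound. Among these compounds, the comparison with the dimethylamino group gives a number 4 percentage points lower from compound 1 to compound 4 (within the scatter), which means that all three groups now tried at this carbon, dimethylamino, chloro and fluoro, lie within the scatter of one another, a wider spread of group types than the single earlier step covered. No measurement bears on why the numbers stay level across these exchanges.

Each of these readings comes from one concentration, so any differences in potency among the three compounds remain unresolved. As far as these compounds go, whether a carboxylic acid or a longer alkyl chain at this carbon would keep the same level of inhibition also stays open.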